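From Cyclohexylmethyl Back to a Methoxyphenoxy Group

The source may report more compounds than this note shows. Statements on the series, on what has been measured and on what is new or still open speak of the compounds shown alone.

Three measured compounds share one core and differ only at a single aromatic carbon. Compound 1 `COc1ccccc1Oc1ccc2c(NCCCNCc3ccco3)ccnc2c1` carries a 2-methoxyphenoxy group there, and in an ADME assay for permeability, using PAMPA, with a stated time of 30 min, at pH 7.4 (on this read-out higher numbers stand for higher permeability and lower numbers for lower permeability), compound 1 gives 317 10^-6 cm/s. Compound 2 `Clc1ccc(Oc2ccc3c(NCCCNCc4ccco4)ccnc3c2)cc1` carries a 4-chlorophenoxy group instead, and in this assay compound 2 gives 317 10^-6 cm/s; no change at the digits printed from compound 1 to compound 2 (within the scatter). Compound 3 `c1coc(CNCCCNc2ccnc3cc(CC4CCCCC4)ccc23)c1` has a cyclohexylmethyl group at that carbon, and in this assay compound 3 gives 23 10^-6 cm/s, the lowest of the three numbers. Both steps that lead to it are large: a 14-fold lower number from compound 1 to compound 3 (1.14 log units; beyond the scatter), and a 14-fold lower number from compound 2 to compound 3 (1.14 log units; beyond the scatter).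

Compound 4 `COc1ccc(Oc2ccc3c(NCCCNCc4ccco4)ccnc3c2)cc1` has not been measured yet. It differs from compound 3 in one place: 4-methoxyphenoxy in place of cyclohexylmethyl on an aromatic carbon. This change runs opposite to the two large steps just described: it puts a methoxyphenoxy group on the aromatic carbon where compound 3 has cyclohexylmethyl. The two groups that left in those steps, 2-methoxyphenoxy and 4-chlorophenoxy, gave numbers within the scatter of each other. A large rise in this assay is therefore expected, of about a 13-fold higher number from compound 3 to compound 4 (1.12 log units; beyond the scatter) for compound 4. The estimate for compound 4 in this assay is 300 10^-6 cm/s, with a range from 150 10^-6 cm/s to 550 10^-6 cm/s.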

Compound 4, apparent permeability: 317 10^-6 cm/s
Compound 4: the middle estimate sits 1.1-fold (0.02 log units) below what was measured; low and high end bracket the measured number.
By their numbers in this assay, from the lowest: compound 3; then compounds 1, 2 and 4 (each within the scatter of the next).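

Compound 4 shows that the large gap at this aromatic carbon also appears in the opposite direction in this assay: with 4-methoxyphenoxy in place of cyclohexylmethyl, the step is a 14-fold higher number from compound 3 to compound 4 (1.14 log units; beyond the scatter), and a third group joined through oxygen now stands apart from cyclohexylmethyl. Exchanging 4-methoxyphenyl for 2-methoxyphenyl on that oxygen gives no change at the digits printed from compound 1 to compound 4 (within the scatter), while methoxy in place of chloro gives no change at the digits printed from compound 2 to compound 4 (within the scatter), so neither the place of the methoxy on the outer ring nor this exchange of methoxy for chloro separates these compounds. Among the four compounds, compound 3 alone stands apart from the others, and no measurement at hand explains that gap.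

Oxygen and an aromatic ring enter together in every step away from cyclohexylmethyl, so these compounds cannot show which of the two goes with the higher number; a benzyl group, with its aromatic ring but no oxygen, and a cyclohexyloxy group, with its oxygen but no aromatic ring, would pull the two apart. On these data alone, how an amine or a carboxylic acid on the outer ring would read in this assay also remains open.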